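The source may report more compounds than this note shows. Statements on the series, on what has been measured and on what is new or still open speak of the compounds shown alone.

Measured so far:
compound 1, `O=C1OC(c2ccc(Cl)cc2)=C/C1=C\c1ccc(Cl)cc1`: 69.1%
compound 2, `O=C1OC(c2ccc(Cl)cc2)=C/C1=C\c1ccc([N+](=O)[O-])cc1`: 36%
compound 3, `O=C1/C(=C/c2ccc(Cl)cc2)C=C(c2ccc(Cl)cc2)N1Cc1ccccc1`: 88.9%

In a functional assay on the whole organism (strain Wistar) for inhibition, with Rattus norvegicus as the target, with stated times of 30 min and 3 h, at a dose of 20 mg/kg by the oral route (on this read-out lower numbers stand for less inhibition and higher numbers for more inhibition at the one dose given (going by the name of the read-out)), compound 1 gives 69.1%, compound 2 gives 36%, and compound 3 gives 88.9%, the highest of the three.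

Compound 1 and compound 2 differ in one place only: nitro in place of chloro on an aromatic carbon. That change made a number 33.1 percentage points lower from compound 1 to compound 2 (beyond the scatter).

Compound 3 rests on a different core; the difference between the two cores is not broken down here. Compound 4, `O=C1/C(=C/c2ccc([N+](=O)[O-])cc2)C=C(c2ccc(Cl)cc2)N1Cc1ccccc1`, carries the same change on that core: nitro in place of chloro on an aromatic carbon. The place is described in the same words for both pairs, so it is the same change.

If it acts alike here, a step of about a number 31.9 percentage points lower from compound 3 to compound 4 (beyond the scatter) is expected, resting on a number 33.1 percentage points lower from compound 1 to compound 2 (beyond the scatter). Compound 4 is therefore estimated at 57%, most likely between 40% and 75%.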

Compound 4, a percentage reported as inhibition, in the whole organism at one dose (the size of the read-out at that dose, not a potency): 19.8%
Estimate against measurement, compound 4: 37.2 percentage points above; measured number outside the range, below it.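

Putting nitro in place of chloro on the core of compound 3 gives a number 69.1 percentage points lower from compound 3 to compound 4 (beyond the scatter) in this assay. The change lowers the number on both cores, so its direction carries across this one pair of cores, but its size does not: the same change on two cores in this assay, a number 33.1 percentage points lower (beyond the scatter) from compound 1 to compound 2 and a number 69.1 percentage points lower (beyond the scatter) from compound 3 to compound 4, 36 percentage points apart, beyond the scatter of two such steps. This does not show what in the core sets the size of the step, nor how the change would behave on any further core.

The compounds shown leave open whether an amine or a carboxylic acid in that place would also give a lower number on both cores. They also leave open whether the two cores would then differ as widely.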